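Ortho-Chloro on the Benzyl Group of Compound 2

This account rests on a few compounds, and the source may have more. Where it says the series, first, only, none or still open, it means among the compounds named here.

Measured compounds:
Compound 1, `CN(C)Cc1ccc2nc(NC(=O)N/N=C/c3cn(Cc4ccc(Cl)cc4)c4ccccc34)sc2c1`, gives 290 nM in a functional assay on NCI-H460 cells (Homo sapiens) for cytotoxicity, read by MTT assay, with a stated time of 72 h; a lower number here means a stronger inhibitor, a higher number a weaker inhibitor.
Compound 2, `CCN(CC)Cc1ccc2nc(NC(=O)N/N=C/c3cn(Cc4ccccc4)c4ccccc34)sc2c1`, gives 450 nM in this assay.
Compound 3, `CN(C)Cc1ccc2nc(NC(=O)N/N=C/c3cn(Cc4ccc(Cl)cc4Cl)c4ccccc34)sc2c1`, gives 950 nM in this assay.

Compound 1 and compound 3 share a core and differ by chloro in place of hydrogen on an aromatic carbon, a change that gave a 3.3-fold higher number from compound 1 to compound 3 (0.52 log units; beyond the scatter). Compound 2 differs from compound 1 in a way that is not broken down here; its value in this assay stands within the scatter of compound 1 and beyond the scatter of compound 3.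

Compound 4, `CCN(CC)Cc1ccc2nc(NC(=O)N/N=C/c3cn(Cc4ccccc4Cl)c4ccccc34)sc2c1`, has not yet been measured. It differs from compound 2 by chloro in place of hydrogen on an aromatic carbon. Going by the values given here, this is the same kind of change as the one from compound 1 to compound 3, but not the same: in compound 3 the entering chloro also sits meta to a chloro group, whereas in compound 4 the ring carries no other chloro.

Among the compounds with values here, because compound 1 to compound 3 gave a 3.3-fold higher number from compound 1 to compound 3 (0.52 log units; beyond the scatter), the expectation for the step from compound 2 to compound 4 is an increase of about a 2.4-fold higher number from compound 2 to compound 4 (0.39 log units; beyond the scatter), estimated somewhat smaller than the measured one since only one example of the change is known and its surroundings differ. Compound 4 is therefore expected to give about 1100 nM, with an estimated range from 500 nM to 2500 nM.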

Compound 4, half-maximal inhibitory concentration: 980 nM
For compound 4 the middle estimate is 1.1-fold (0.05 log units) above the measured one, within the range that was stated.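

In this assay, exchanging benzyl for 2-chlorobenzyl gave a 2.2-fold higher number from compound 2 to compound 4 (0.34 log units; beyond the scatter) and so went in the same direction as the earlier chloro step, with the number rising rather than falling on the second core as well. Set side by side, the two steps cannot be told apart in size, and on these two cores the change carried over in both direction and approximate magnitude: the same change on two cores in this assay, a 3.3-fold higher number (0.52 log units; beyond the scatter) from compound 1 to compound 3 and a 2.2-fold higher number (0.34 log units; beyond the scatter) from compound 2 to compound 4, 1.5-fold (0.18 log units) apart, within the scatter of two such steps. Going by these compounds alone, this does not show a general rule: it rests on only one pair of compounds from each core, the chloro enters a ring that carries another chloro in one pair and no other chloro in the other, and nothing here explains why the number rises.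

The compounds shown leave open whether a chloro ortho to a large group on the benzyl ring would give a similar step on the core of compound 1, and whether the same step would hold with a pyrrolidine or morpholine in place of the dimethylamino or diethylamino group. They also leave open whether a fluoro, methyl or methoxy group at the same place on the ring would move the number in the same way as chloro.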